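Replacing piperidinyl by methyl on the sulfonamide-bearing ring

The source may hold more compounds than are shown below. What is called first, only, known or untested is meant among the compounds shown, and "the series" means these compounds.

Compound 1, `CC(C(=O)NCc1ccc(C(C)(C)C)cc1)c1ccc(NS(C)(=O)=O)c(Cl)c1`: 30.7 nM in an assay on CHO cells for displacement of a labelled ligand from transient receptor potential cation channel subfamily V member 1 (Rattus norvegicus), read by scintillation counting, with a stated time of 60 min; on this read-out higher numbers stand for weaker inhibition and lower numbers for stronger inhibition
Compound 2, `CC(C(=O)NCc1ccc(C(C)(C)C)cc1)c1ccc(NS(C)(=O)=O)c(I)c1`: 23.3 nM in this assay
Compound 3, `CC(C(=O)NCc1ccc(C(C)(C)C)cc1)c1ccc(NS(C)(=O)=O)c(N2CCCCC2)c1`: "active" (no number reported) in this assay, without a number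

Compound 3 therefore has no fixed place among the numbers; all that is known is that it shows activity in this assay, so its distance from compound 1 and compound 2 cannot be stated.

Compound 4, `Cc1cc(C(C)C(=O)NCc2ccc(C(C)(C)C)cc2)ccc1NS(C)(=O)=O`, differs from compound 3 by methyl in place of piperidin-1-yl on an aromatic carbon. Among the compounds with values here, no measured step covers this exchange. Within the data shown here, the only measured step at the same ring position is a 1.3-fold lower number from compound 1 to compound 2 (0.12 log units; within the scatter), which shows that two different substituents there give numbers within the usual scatter of one another. On that basis, and with no number for compound 3 to anchor a step, the working assumption is that a methyl at this position will leave compound 4 in the same region as compound 1 and compound 2, with no shift beyond the scatter expected in either direction.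

Compound 4 is accordingly estimated at 30 nM in this assay, with a range from 10 nM to 90 nM.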

Compound 4, inhibition constant: 32.8 nM
For compound 4 the middle estimate is 1.1-fold (0.04 log units) below the measured one; the range from low to high includes it.
By their numbers in this assay, from the lowest: compounds 2, 1 and 4 (each within the scatter of the next).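

In this assay the exchange of iodo for methyl on the aromatic carbon ortho to a methanesulfonamido group amounts to a 1.4-fold higher number from compound 2 to compound 4 (0.15 log units; within the scatter) and the exchange of chloro for methyl amounts to a 1.1-fold higher number from compound 1 to compound 4 (0.03 log units; within the scatter) at the same position. The earlier pair covered only two halogens here, whereas methyl now adds a carbon substituent, and chloro, iodo and methyl all give numbers within the usual scatter of one another, so among these compounds a halogen is not needed for a number in this region. Nothing at hand gives a reason for this result.

Going by these compounds, compound 3 carries only the label "active" without a number, so the exchange of piperidin-1-yl for methyl cannot be read, and the effect of the larger ring at this position stays unknown. Whether the same region holds for a primary amine, a carboxylic acid or a longer chain such as n-butyl at this aromatic carbon also remains open, as the compounds shown stop at chloro, iodo and methyl among the groups with numbers.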